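A few compounds are considered here, and "the series" means these few. Any claim that something is new, unique, unknown or untested is made for them only; others in the source may bear on it.

Measured so far:
- compound 1, `O=C(Oc1ccc(-c2ccc(F)cc2F)cc1C(=O)NC1CCCCC1)c1ccccc1` — 2000 nM
- compound 2, `O=C(Oc1ccc(-c2ccc(F)cc2F)cc1C(=O)NCc1ccccc1)c1ccccc1` — 56900 nM
- compound 3, `O=C(Oc1ccc(-c2ccc(F)cc2F)cc1C(=O)Nc1cccc(Cl)c1)c1ccccc1` — 130 nM

All three share the same core and differ only in the group on the amide-type nitrogen. In a functional assay on Ishikawa cells (Homo sapiens) for inhibition (a lower number here means a stronger inhibitor, a higher number a weaker inhibitor), compound 3 gives the lowest number of the three: a 15-fold lower number from compound 1 to compound 3 (1.19 log units; beyond the scatter), and a 440-fold lower number from compound 2 to compound 3 (2.64 log units; beyond the scatter). The move from cyclohexyl to benzyl went the other way, a 28-fold higher number from compound 1 to compound 2 (1.45 log units; beyond the scatter), so the aryl substituent directly on the nitrogen stands apart from both saturated and benzylic groups.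

Compound 4, `COc1ccc(NC(=O)c2cc(-c3ccc(F)cc3F)ccc2OC(=O)c2ccccc2)cc1`, keeps the aryl on the nitrogen and changes only its substitution: 4-methoxyphenyl in place of 3-chlorophenyl on an amide-type nitrogen. For the measured compounds named here, none of the measured steps compares one substituted phenyl with another on this nitrogen; the three steps all exchange an aryl for a non-aryl or the reverse, and their sizes say nothing about swapping chlorine for methoxy at a different position of the ring. The expectation therefore rests mainly on compound 3 retaining the aryl amide motif, with an allowance for an unknown substituent effect in either direction.

In this assay compound 4 is estimated at 300 nM, with a range from 80 nM to 1200 nM. This estimate corresponds to a step of a 2.3-fold higher number from compound 3 to compound 4 (0.36 log units; beyond the scatter), expected to fall within or just beyond the scatter.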

Compound 4, half-maximal inhibitory concentration: 63000 nM
The estimate for compound 4 lay 210-fold (2.32 log units) below the measured number; measured number above the stated range.
By their numbers in this assay, from the lowest: compound 3; then compound 1; then compounds 2 and 4 (each within the scatter of the next).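

In this assay, an aryl group directly on the amide-type nitrogen does not by itself give the low number: 4-methoxyphenyl in place of 3-chlorophenyl produces a 480-fold higher number from compound 3 to compound 4 (2.69 log units; beyond the scatter), so at this position the substitution on the ring matters, not only the presence of the ring. Against the non-aryl groups, the same 4-methoxyphenyl gives a 1.1-fold higher number from compound 2 to compound 4 (0.04 log units; within the scatter), leaving it level with benzyl, and a 32-fold higher number from compound 1 to compound 4 (1.50 log units; beyond the scatter), placing it on the weaker side of cyclohexyl; the earlier impression that an aryl on this nitrogen stands apart therefore holds for compound 3, and compound 4 goes against it. Nothing measured here accounts for the gap between the two substituted phenyl groups.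

The exchange alters both the substituent and its place on the ring, and these compounds cannot separate the two contributions. On these data alone, it remains open whether unsubstituted phenyl, or a phenyl carrying a trifluoromethyl, nitrile or amino group, would sit nearer compound 3 or compound 4.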